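A few compounds are considered here, and "the series" means these few. Any claim that something is new, unique, unknown or untested is made for them only; others in the source may bear on it.

Measured compounds:
compound 1, `CCOC(=S)SCC(=O)c1ccc(OC)cc1`: 448 nM
compound 2, `CCSC(=S)SCC(=O)c1ccc(C(=O)NCCOc2ccccc2)cc1`: 483 nM

Both compounds were tested in an assay on HEK293 cells for inhibition of protein deacetylase HDAC6 (Homo sapiens); on this read-out lower numbers stand for stronger inhibition and higher numbers for weaker inhibition. Compound 1 `CCOC(=S)SCC(=O)c1ccc(OC)cc1` gives 448 nM, and compound 2 `CCSC(=S)SCC(=O)c1ccc(C(=O)NCCOc2ccccc2)cc1` gives 483 nM. Compound 2 carries the higher of the two numbers, yet its gap to compound 1 lies within the scatter of repeated measurements, so the two values cannot be told apart.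

Compound 3 `CCSC(=S)SCC(=O)c1ccc(C(=O)Nc2ccccc2)cc1` has not yet been measured. It differs from compound 2 in one place: phenyl in place of 2-phenoxyethyl on an amide-type nitrogen. Within the data shown here, no measured pair shows the effect of this change, so nothing in the data points to a direction. The step is therefore expected to be small, and the estimated value from compound 2 to compound 3 is a 1.1-fold higher number from compound 2 to compound 3 (0.03 log units; within the scatter), which is not beyond the scatter. For compound 3 the expected result in this assay is 520 nM, with a range from 200 nM to 1400 nM.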

Compound 3, half-maximal inhibitory concentration: 521 nM
Compound 3: middle estimate off by 1.0-fold (0.00 log units), on the low side; low and high end bracket the measured number.
By their numbers in this assay, from the lowest: compounds 1, 2 and 3 (each within the scatter of the next).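

In this assay, among these compounds, the exchange of 2-phenoxyethyl for phenyl on an amide-type nitrogen gives a 1.1-fold higher number from compound 2 to compound 3 (0.03 log units; within the scatter) and is the first change at this position that can be read. The ring stays while the ethyl-oxygen linker leaves, with fewer heavy atoms and no hydrogen-bond acceptor in the entering group, and the read-out does not separate the two groups. Nothing measured here offers a reason for this result.

On these data alone, whether a different group on that nitrogen, such as benzyl, a longer chain or a chain ending in an amine or a carboxylic acid, would move the number beyond the scatter remains open. Equally open, as far as these compounds go, is whether a methyl group in place of the amide hydrogen would matter.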